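This account rests on a few compounds, and the source may have more. Where it says the series, first, only, none or still open, it means among the compounds named here.

Compound 1 `Nc1ccc2cccc(OCCC(F)(F)F)c2n1`: 722 nM
Compound 2 `CCCC(C)Oc1cccc2ccc(N)nc12`: 105 nM
Compound 3 `CC(C)(C)CCOc1cccc2ccc(N)nc12`: 201 nM

In an assay on cells with melanin-concentrating hormone receptor 1 (Homo sapiens) as the target, read by radioligand binding (a higher number here means a weaker inhibitor, a lower number a stronger inhibitor), compound 3 gives 201 nM. Its number lies well under that of compound 1, a 3.6-fold lower number from compound 1 to compound 3 (0.56 log units; beyond the scatter), while the gap to compound 2, a 1.9-fold higher number from compound 2 to compound 3 (0.28 log units; within the scatter), does not separate the two. Compound 4 `CCC#CCOc1cccc2ccc(N)nc12` keeps the shared core and changes only the chain on the oxygen: but-1-yn-1-yl in place of neopentyl on a saturated chain carbon bound to an oxygen on an aromatic ring. The measured steps all concern this chain; the two large ones, a 6.9-fold lower number from compound 1 to compound 2 (0.84 log units; beyond the scatter) and a 3.6-fold lower number from compound 1 to compound 3 (0.56 log units; beyond the scatter), replace the fluorinated chain, and the one between branched alkyl chains, a 1.9-fold higher number from compound 2 to compound 3 (0.28 log units; within the scatter), stays within scatter. For compound 4 the step of a 1.2-fold higher number from compound 3 to compound 4 (0.09 log units; within the scatter) is therefore expected to be small, and its value is estimated at 250 nM, within 100 nM to 700 nM.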

Compound 4, half-maximal inhibitory concentration: > 2000 nM
Compound 4: no number, only a limit (the forecaster's own chance of this, stated with the estimate: 3%); middle value at least 8.0-fold (0.90 log units) away from the limit.
By their numbers in this assay, from the lowest: compounds 2 and 3 (each within the scatter of the next); then compound 1. At a limit, above all of these: compound 4.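

The reading for compound 4 in this assay is a limit of the assay and not a number: the limit of > 2000 nM in this assay, at which 1 of the 4 values shown sits.

The chain on the oxygen, whose earlier steps were modest or within the scatter, here gives a much larger change when pent-2-yn-1-yl, with its triple bond, enters: an at least 9.9-fold higher number from compound 3 to compound 4 (0.99 log units; beyond the scatter) and an at least 19-fold higher number from compound 2 to compound 4 (1.27 log units; beyond the scatter). Compound 4 also stands beyond the fluorinated chain of compound 1, with an at least 2.7-fold higher number from compound 1 to compound 4 (0.44 log units; beyond the scatter).

On these data alone, how far compound 4 lies past its limit remains open. As far as these compounds go, whether the triple bond alone sets this result also remains open, and an unbranched pentyl chain on the same oxygen would address that.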